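The compounds below may be only part of what the source reports. "The series", "measured", "known", "first", "only" and "open" are said of these compounds alone.

Measured in an ADME assay on microsomes from liver (Mus musculus, strain CD-1) for metabolic stability, read by LC-MS, with a stated time of 60 min, tested at 20 uM; a lower number here means that the compound disappears faster, a higher number that the compound lasts longer:
- compound 1 `CC(Sc1nc2c(cnn2C)c(=O)n1-c1ccccc1)c1ccccn1`: 0.833 h
- compound 2 `O=c1c2cn(C3COC3)nc2nc(SCc2cccc(F)c2)n1-c1ccccc1`: 0.383 h
- compound 3 `COc1cccc(C(C)Sc2nc3c(cnn3C)c(=O)n2-c2ccccc2)c1`: 0.1 h

Compound 1 has the highest number of the three. The unmeasured compound 4 `Cn1ncc2c(=O)n(-c3ccccc3)c(SCc3cccc(F)c3)nc21` carries 3-fluorobenzyl in place of 1-(pyridin-2-yl)ethyl on a sulfur. One measured step also removes the pyridin-2-yl group: an 8.3-fold lower number from compound 1 to compound 3 (0.92 log units; beyond the scatter). The core differs, but compound 2 carries the same 3-fluorobenzyl on its sulfur and gives 0.383 h. A lower number is therefore expected. Its size is expected to be nearer the gap from compound 1 to compound 2 than the full step from compound 1 to compound 3. The expected change in this assay is estimated as a 2.8-fold lower number from compound 1 to compound 4 (0.44 log units; beyond the scatter). For compound 4 the estimate is 0.3 h, with an expected range of 0.12 h to 0.7 h.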

Compound 4, half-life: 0.133 h
Beside the measured number, compound 4's estimate is 2.3-fold (0.35 log units) above it; measured number inside the range.
By their numbers in this assay, from the lowest: compounds 3 and 4 (each within the scatter of the next); then compound 2; then compound 1.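

In this assay, 3-fluorobenzyl in place of 1-(pyridin-2-yl)ethyl on a sulfur of the shared core gives a 6.3-fold lower number from compound 1 to compound 4 (0.80 log units; beyond the scatter). With compound 3 and compound 4 within the scatter of each other, both groups lacking the pyridin-2-yl ring fall at a similar level, well under compound 1. No measurement shown accounts for this step.

Going by these compounds, this change replaces the pyridin-2-yl ring and removes the ethyl branch together, so the share of each remains open. Pyridin-2-ylmethyl on the sulfur would separate the two.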